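The source may hold more compounds than are shown below. What is called first, only, known or untested is meant among the compounds shown, and "the series" means these compounds.

Measured so far: compound 1 `Cc1ccc2nc(Nc3nc(Nc4ccc(S(N)(=O)=O)cc4)ncc3F)sc2c1` with 4960 nM in a functional assay on PC-3 cells (Homo sapiens) for antiproliferative activity, read by MTT assay, with a stated time of 48 h; a lower number here means a stronger inhibitor, a higher number a weaker inhibitor; compound 2 `NS(=O)(=O)c1ccc(Nc2ncc(F)c(Nc3nc4ccccc4s3)n2)cc1`, whose result in this assay is only the limit > 50000 nM; compound 3 `CS(=O)(=O)c1ccc(Nc2nccc(Nc3nc4ccc(F)cc4s3)n2)cc1` with 1940 nM in this assay.

From compound 2 to compound 1 the change is methyl in place of hydrogen on an aromatic carbon, and it gives an at least 10-fold lower number from compound 2 to compound 1 (1.00 log units; beyond the scatter); the step is open-ended because compound 2 sits at the limit of > 50000 nM in this assay, at which 1 of the 3 values shown sits. The difference between the core of compound 2 and the core of compound 3 is not broken down here; compound 3 shows the lower of the two numbers.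

Compound 4 `Cc1cnc(Nc2ccc(S(C)(=O)=O)cc2)nc1Nc1nc2ccc(F)cc2s1` is still to be tested. It differs from compound 3 by methyl in place of hydrogen on an aromatic carbon, the same kind of change as from compound 2 to compound 1, but the place differs: there the methyl entered on a ring of carbon only, meta and para to a fused ring, here on a ring with 2 nitrogen, ortho and para to a large group and two atoms from the ring nitrogen. Resting on the gain from compound 2 to compound 1 in this assay, with the caution that the place is not the same, the step from compound 3 to compound 4 is expected to be a 1.9-fold lower number from compound 3 to compound 4 (0.29 log units; within the scatter). Compound 4 is therefore estimated at 1000 nM, between 300 nM and 4000 nM.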

Compound 4, half-maximal inhibitory concentration: > 50000 nM
Compound 4 gave a limit, no number; the forecaster's own chance of this, stated with the estimate: 5%; middle value at least 50-fold (1.69 log units) from the limit.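

In this assay, methyl in place of hydrogen on an aromatic carbon gave an at least 25-fold higher number from compound 3 to compound 4 (1.41 log units; beyond the scatter), so the gain seen on the other core did not carry over, and the two steps differ: the same change on two cores in this assay, an at least 10-fold lower number (1.00 log units; beyond the scatter) from compound 2 to compound 1 and an at least 25-fold higher number (1.41 log units; beyond the scatter) from compound 3 to compound 4, at least 250-fold (2.41 log units) apart, beyond the scatter of two such steps. Neither step rests on two numbers, since each has one end at a limit of the assay: the limit of > 50000 nM in this assay, at which 2 of the 4 values shown sit. The methyl also sits in a different place in each pair and the cores differ, so these two pairs cannot separate place from core and give no rule for the series.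

The compounds shown leave open whether another group on the ring with 2 nitrogen, such as ethyl or an amine, would fare differently from methyl. They also leave open how methyl would behave at that place on the core of compound 1.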